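Replacing pyrrolidin-1-yl by piperidin-1-yl: working notes

The source may report more compounds than this note shows. Statements on the series, on what has been measured and on what is new or still open speak of the compounds shown alone.

In a functional assay on OVCAR-3 cells (Homo sapiens) for antiproliferative activity, read by sulforhodamine B assay, with a stated time of 48 h (on this read-out higher numbers stand for weaker inhibition of growth and lower numbers for stronger inhibition of growth), compound 2 `CCCCCCCC/C=C\CCCCCCCC(=O)N1CCCC1` gives 11.5 ug/mL. Compound 1 `CCCCCC[C@@H](O)C/C=C\CCCCCCCC(=O)N[C@@H](C)c1ccccc1` gives 11.1 ug/mL, within the scatter of compound 2. Compound 3 `CCCCCCCCCCCCCCCC(=O)N1CCOCC1` gives 33.1 ug/mL, a higher number than compound 2 and beyond the scatter, so compound 2 shows stronger inhibition of growth than compound 3 and cannot be told apart from compound 1.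

Compound 4 `CCCCCCCC/C=C\CCCCCCCC(=O)N1CCCCC1` has not yet been measured. Its change from compound 2 is piperidin-1-yl in place of pyrrolidin-1-yl on a carbonyl carbon. Going by the values given here, no two measured compounds here differ in one place only, so the set offers no direct precedent for this change. Compound 1 and compound 3 each differ from compound 2 in more than one place and serve only as loose bounds on the numbers.

The reference point is therefore compound 2 at 11.5 ug/mL, and no step beyond the scatter is expected in this assay. The expected step is a 1.1-fold higher number from compound 2 to compound 4 (0.05 log units; within the scatter). For compound 4 the estimated value is 13 ug/mL, with an expected range of 6.5 ug/mL to 26 ug/mL.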

Compound 4, concentration for 50% growth inhibition: 9.3 ug/mL
Beside the measured number, compound 4's estimate is 1.4-fold (0.15 log units) above it; the measured number falls inside the stated range.
By their numbers in this assay, from the lowest: compounds 4, 1 and 2 (each within the scatter of the next); then compound 3.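

In this assay, the change from pyrrolidin-1-yl to piperidin-1-yl on a carbonyl carbon gives the series its first comparison in one place only, a 1.2-fold lower number from compound 2 to compound 4 (0.09 log units; within the scatter), and this step stays within the scatter. At this position the five-membered ring can therefore give way to the six-membered ring, which adds one carbon and leaves the count of hydrogen-bond donors and acceptors unchanged, with no difference that this read-out can resolve. Nothing available here bears on why the two rings read alike.

On these data alone, this is a single step on a single chain, so it remains open whether the same holds for a larger ring such as azepan-1-yl, or for piperazin-1-yl, which brings a second ring nitrogen to the same carbonyl carbon. As far as these compounds go, it also remains open whether the swap of pyrrolidin-1-yl for piperidin-1-yl reads the same on a longer chain, or on a chain carrying a hydroxyl group like that of compound 1.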